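Cyclobutyl side-chain variation in a kinase inhibitor series

The source may report more compounds than this note shows. Statements on the series, on what has been measured and on what is new or still open speak of the compounds shown alone.

Compound 1 `N#Cc1cnc(NCc2cnccc2C(F)(F)F)cc1NC[C@H]1C[C@@H](O)C1` bears the (3-hydroxycyclobutyl)methyl group on a nitrogen on an aromatic ring. In an assay on isolated protein for inhibition of protein kinase C theta type (Homo sapiens), read by TR-FRET, with a stated time of 2 h (on this read-out lower numbers stand for stronger inhibition and higher numbers for weaker inhibition), compound 1 gives 300 nM, the higher of the two numbers recorded so far; compound 2 `CC1(C)C[C@H](Nc2cc(NCc3cnccc3C(F)(F)F)ncc2C#N)CC(C)(C)[C@H]1O` gives 20 nM in this assay, a gap beyond the usual scatter. Compound 3 `CC1(C)[C@H](Nc2cc(NCc3cnccc3C(F)(F)F)ncc2C#N)C[C@H]1C(N)=O` differs from compound 1 by 3-carbamoyl-2,2-dimethylcyclobutyl in place of (3-hydroxycyclobutyl)methyl on a nitrogen on an aromatic ring. For the measured compounds named here, no measured pair isolates this change, so its size is unknown. Compound 2, at 20 nM, shows that other groups on this nitrogen reach stronger inhibition, so a step toward a lower number is expected. Compound 3 is expected near 60 nM, within 15 nM to 250 nM, an expected step of a 5.0-fold lower number from compound 1 to compound 3 (0.70 log units; beyond the scatter).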

Compound 3, half-maximal inhibitory concentration: 140 nM
Estimate against measurement, compound 3: 2.3-fold (0.37 log units) below; measured number inside the range.
By their numbers in this assay, from the lowest: compound 2; then compound 3; then compound 1.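

In this assay, 3-carbamoyl-2,2-dimethylcyclobutyl in place of (3-hydroxycyclobutyl)methyl gives a 2.1-fold lower number from compound 1 to compound 3 (0.33 log units; beyond the scatter), so this nitrogen accepts a carbamoyl-bearing cyclobutyl group with a modest gain. The step bundles several differences in one change: the methyl link, the two added methyl groups and the carbamoyl in place of hydroxy. No measurement at hand bears on the reason for the shift.

Which of these differences carries the step stays open. A 3-hydroxy-2,2-dimethylcyclobutyl group or a carboxylic acid in place of the carbamoyl would help separate them.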